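Dropping the Methoxy Group from the Aryl Ring

The source may hold more compounds than are shown below. What is called first, only, known or untested is meant among the compounds shown, and "the series" means these compounds.

Compound 3 `CCC1=C(O)c2c(oc(-c3ccc(OC)cc3C)cc2=O)C(CC)(CC)C1=O` carries the lowest of the three numbers in a functional assay on KB cells (Homo sapiens) for antiproliferative activity, read by sulforhodamine B assay, with a stated time of 3 days (on this read-out higher numbers stand for an effect only at larger amounts of compound and lower numbers for an effect already at smaller amounts), giving 20.9 uM, although its gap to compound 1 lies within the scatter. Compound 1 `CCC1=C(O)c2c(oc(-c3ccc(C)cc3)cc2=O)C(CC)(CC)C1=O` gives 39.2 uM, with a 1.9-fold lower number from compound 1 to compound 3 (0.27 log units; within the scatter). For the measured compounds named here, compound 2 `CCC1=C(O)c2c(oc(-c3cccc(C)c3)cc2=O)C(CC)(CC)C1=O` gives 49.7 uM, and a 2.4-fold lower number from compound 2 to compound 3 (0.38 log units; beyond the scatter) is the only step beyond the scatter. Compound 4 `CCC1=C(O)c2c(oc(-c3cc(C)ccc3C)cc2=O)C(CC)(CC)C1=O` differs from compound 3 by 2,5-dimethylphenyl in place of 4-methoxy-2-methylphenyl on an aromatic carbon. The step of a 1.3-fold higher number from compound 1 to compound 2 (0.10 log units; within the scatter) shows no effect beyond the scatter for a methyl alone, whereas the entry of the 4-methoxy-2-methylphenyl group in a 1.9-fold lower number from compound 1 to compound 3 (0.27 log units; within the scatter) and a 2.4-fold lower number from compound 2 to compound 3 (0.38 log units; beyond the scatter) brought the lower numbers. Compound 4 gives up the methoxy. For compound 4 a step back toward the higher numbers of compound 1 and compound 2 is therefore expected, a 1.7-fold higher number from compound 3 to compound 4 (0.22 log units; within the scatter). Compound 4 is estimated at 35 uM, within 15 uM to 80 uM.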

Compound 4, concentration for half-maximal effect: 14.5 uM
Compound 4: the middle estimate sits 2.4-fold (0.38 log units) above what was measured; the whole stated range lies above it.
By their numbers in this assay, from the lowest: compounds 4, 3, 1 and 2 (each within the scatter of the next, the first and the last beyond it).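

In this assay, 2,5-dimethylphenyl in place of 4-methoxy-2-methylphenyl gives a 1.4-fold lower number from compound 3 to compound 4 (0.16 log units; within the scatter), so among these compounds the low numbers do not depend on the methoxy group. Methyl in place of hydrogen on the aryl ring of compound 2 gives a step beyond the scatter, a 3.4-fold lower number from compound 2 to compound 4 (0.53 log units; beyond the scatter), and the change from 4-methylphenyl gives a 2.7-fold lower number from compound 1 to compound 4 (0.43 log units; beyond the scatter). Nothing available explains these steps.

The compounds shown leave open whether an amine or a chlorine on the aryl ring would keep numbers this low.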